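The source may hold more compounds than are shown below. What is called first, only, known or untested is meant among the compounds shown, and "the series" means these compounds.

Measured in a functional assay on CCRF-CEM cells (Homo sapiens) for antiproliferative activity; on this read-out higher numbers stand for weaker inhibition and lower numbers for stronger inhibition:
- compound 1 `COc1cc(C(=O)c2sc(-c3cccc([N+](=O)[O-])c3)cc2N)cc(OC)c1OC`: 5.9 nM
- compound 2 `COc1cc(C(=O)c2sc(-c3ccncc3)cc2N)cc(OC)c1OC`: 110 nM
- compound 3 `COc1cc(C(=O)c2sc(-c3cc(OC)c(OC)c(OC)c3)cc2N)cc(OC)c1OC`: 840 nM

Of these three, compound 2 holds the middle place with 110 nM. The number for compound 1 is lower and the number for compound 3 is higher.

The next compound, compound 4 `COc1ccc(-c2cc(N)c(C(=O)c3cc(OC)c(OC)c(OC)c3)s2)cc1`, differs from compound 2 in one place, the aromatic carbon next to the ring sulfur: 4-methoxyphenyl in place of pyridin-4-yl on an aromatic carbon.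

Among the compounds with values here, only one measured step changes this group: a 19-fold higher number from compound 1 to compound 2 (1.27 log units; beyond the scatter). Read backwards, it suggests that replacing pyridin-4-yl with a ring of carbon only could lower the number. Compound 3 warns against relying on this, since its carbon-only ring also carries methoxy groups and it gives 840 nM. The two signals pull in opposite directions, so a moderate change is expected, smaller than the measured step. The expected change is a 3.1-fold lower number from compound 2 to compound 4 (0.50 log units; beyond the scatter). Compound 4 is estimated at 35 nM, with an expected range from 7 nM to 200 nM.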

Compound 4, half-maximal inhibitory concentration: 19 nM
Beside the measured number, compound 4's estimate is 1.8-fold (0.27 log units) above it; the range from low to high includes it.
By their numbers in this assay, from the lowest: compound 1; then compound 4; then compound 2; then compound 3.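

In this assay, the swap of pyridin-4-yl for 4-methoxyphenyl gives a 5.8-fold lower number from compound 2 to compound 4 (0.76 log units; beyond the scatter) on the aromatic carbon next to the ring sulfur, so a carbon-only ring carrying a methoxy group can give a low number here. The same compound does not match the 3-nitrophenyl compound, with a 3.2-fold higher number from compound 1 to compound 4 (0.51 log units; beyond the scatter) here, so these two carbon-only rings are not interchangeable. Compound 3, whose carbon-only ring carries several methoxy groups, gives 840 nM in the same assay, which shows that a carbon-only ring alone does not settle the outcome: what the ring carries matters too.

From the compounds shown here alone, whether a plain phenyl ring, or one carrying an amine or a carboxylic acid, would fall nearer compound 1 or compound 3 remains open. No measurement shown here explains these differences.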